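The compounds below may be only part of what the source reports. "The series", "measured", "known", "first", "only" and "open" are said of these compounds alone.

Measured in an ADME assay on tissue (ZR-75-1 cells, Homo sapiens) for pharmacokinetics; a higher number here means that the compound lasts longer, a lower number that the compound disappears faster:
- compound 1 `CC(C)[C@H](N)C(=O)OC[C@H]1O[C@@H](n2cc(F)c(=O)[nH]c2=O)C[C@@H]1OC(=O)[C@@H](N)C(C)C`: 0.112 h
- compound 2 `N[C@@H](CCC(=O)O[C@H]1C[C@H](n2cc(F)c(=O)[nH]c2=O)O[C@@H]1CO)C(=O)O`: 0.132 h
- compound 3 `N[C@@H](CC(=O)O[C@H]1C[C@H](n2cc(F)c(=O)[nH]c2=O)O[C@@H]1CO)C(=O)O`: 0.403 h

Compound 3 stands highest of the three at 0.403 h, and the other two values lie close together. The next compound to be measured is compound 4 `CC(C)[C@H](N)C(=O)O[C@H]1C[C@H](n2cc(F)c(=O)[nH]c2=O)O[C@@H]1CO`. Going to it from compound 3, 1-amino-2-methylpropyl takes the place of 2-amino-2-carboxyethyl on a carbonyl carbon (1-amino-2-methylpropyl in place of 2-amino-2-carboxyethyl on a carbonyl carbon).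

Among the measured compounds shown here, only one measured step bears on this site, a 3.1-fold higher number from compound 2 to compound 3 (0.48 log units; beyond the scatter). It is modest, though beyond the scatter, and it shows that this half-life can respond to a small change in the group. That step does not involve 1-amino-2-methylpropyl, so it gives a sense of size but no direction. For the measured compounds named here, the direction rests on compound 1, the only measured compound carrying the entering group, with its value of 0.112 h. A shorter half-life than that of compound 3 is therefore expected, with an estimated 2.0-fold lower number from compound 3 to compound 4 (0.30 log units; within the scatter). Compound 4 is estimated at 0.2 h, with an expected range of 0.09 h to 0.42 h.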

Compound 4, half-life: 0.153 h
Compound 4: middle estimate off by 1.3-fold (0.12 log units), on the high side; low and high end bracket the measured number.
By their numbers in this assay, from the lowest: compounds 1, 2 and 4 (each within the scatter of the next); then compound 3.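

In this assay, placing 1-amino-2-methylpropyl on the carbonyl carbon instead of 2-amino-2-carboxyethyl gives a 2.6-fold lower number from compound 3 to compound 4 (0.42 log units; beyond the scatter) and leaves compound 3 alone above the other compounds shown. Placing it instead of 3-amino-3-carboxypropyl stays within the scatter, with a 1.2-fold higher number from compound 2 to compound 4 (0.06 log units; within the scatter) as the printed step, so these two groups cannot be told apart here. Hydrogen in place of (1-amino-2-methylpropyl)carbonyl on the oxygen on a saturated carbon also stays within the scatter, with a 1.4-fold higher number from compound 1 to compound 4 (0.14 log units; within the scatter) as the printed step, so the second such group shows no readable effect in this assay.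

No supporting measurement accounts for the gap between compound 3 and the others. From the compounds shown here alone, whether an acetyl group, which has neither the amine nor the carboxylic acid, would fall with compound 3 or with compounds 1, 2 and 4 remains open.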